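A Small Series Resting at the Assay Limit

A few compounds are considered here, and "the series" means these few. Any claim that something is new, unique, unknown or untested is made for them only; others in the source may bear on it.

Three measured compounds share one core, and compound 4 `NNC(=O)CCc1ccncc1-c1ccc2ccccc2c1` is the one still to be tested. In a functional assay on HCT-116 cells (Homo sapiens) for inhibition, read by MTT assay, with a stated time of 72 h (a lower number here means a stronger inhibitor of growth, a higher number a weaker inhibitor of growth), compound 1 `O=C(O)CCc1ccncc1-c1ccc2ccccc2c1` gives > 30000 nM, which is a limit of the assay and not a number. For compound 2 `CNC(=O)COc1ccncc1-c1ccc2ccccc2c1` this assay records "not determined" (no result reported). Compound 3 `O=C(CCc1ccncc1-c1ccc2ccccc2c1)N1CCOCC1` gives > 30000 nM in this assay, again a limit rather than a number. For the measured compounds named here, the only step between measured compounds, a step that the two limits leave unreadable from compound 1 to compound 3, is therefore unreadable, both ends sitting at the limit. Compound 3 thus stands at the limit together with one further value, while the remaining entry carries no number at all.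

Compound 4 differs from compound 3 by aminoamino in place of morpholin-4-yl on a carbonyl carbon. No readable step bears on this change; what the series shows is the limit of > 30000 nM in this assay, at which 2 of the 3 values shown sit. On that basis the step from compound 3 to compound 4 in this assay is expected to be a step that the limit leaves unreadable from compound 3 to compound 4, that is, no shift that can be read beyond the limit. Compound 4 is accordingly estimated at 40000 nM in this assay, with a range from 8000 nM to 150000 nM, and most likely it too will return only a limit.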

Compound 4, concentration for 50% growth inhibition: > 30000 nM
Compound 4 was reported as a limit; the forecaster's own chance of this, stated with the estimate: 75%; the middle value lies beyond the limit too.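

Compound 4, like compound 1 and compound 3, returns only a limit in this assay, so the steps to compound 4 from compound 1 and from compound 3 cannot be read. The compounds shown leave open whether any replacement on this carbonyl carbon changes growth inhibition at all.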